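Sulfonylpiperidinone series: acetamido on the sulfonyl phenyl

The compounds below may be only part of what the source reports. "The series", "measured", "known", "first", "only" and "open" are said of these compounds alone.

Measured compounds:
compound 1 `O=C1/C(=C/c2cccnc2)CN(S(=O)(=O)c2ccccc2)C/C1=C\c1ccccc1F`, in a functional assay on QGY-7703 cells (Homo sapiens) for cytotoxicity, read by MTT assay, with a stated time of 24 h (a lower number here means a stronger inhibitor, a higher number a weaker inhibitor), compound 1 gives 4800 nM
compound 2 `O=C1/C(=C/c2cccnc2)CN(S(=O)(=O)c2ccccc2)C/C1=C\c1ccccc1C(F)(F)F`, in this assay compound 2 gives 6240 nM

For the measured compounds named here, compound 2 holds the highest of the two numbers so far, with compound 1 nearest; the step of a 1.3-fold higher number from compound 1 to compound 2 (0.11 log units; within the scatter) is within the scatter. Compound 3 `CC(=O)Nc1ccc(S(=O)(=O)N2C/C(=C\c3cccnc3)C(=O)/C(=C/c3ccccc3C(F)(F)F)C2)cc1` differs from compound 2 by acetamido in place of hydrogen on an aromatic carbon. Going by the values given here, the only measured step, from compound 1 to compound 2, changes a different ring and gives no guide to this change. Among the compounds with values here, with no bearing step, the expectation in this assay is a 1.0-fold lower number from compound 2 to compound 3 (0.02 log units; within the scatter), no shift beyond the scatter. Compound 3 is thus estimated at 6000 nM, in the range 2500 nM to 15000 nM.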

Compound 3, half-maximal inhibitory concentration: 5380 nM
Compound 3: middle estimate off by 1.1-fold (0.05 log units), on the high side, and the stated range covers the measured number.
By their numbers in this assay, from the lowest: compounds 1, 3 and 2 (each within the scatter of the next).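

In this assay the phenyl to 4-acetamidophenyl change gives a 1.2-fold lower number from compound 2 to compound 3 (0.06 log units; within the scatter) so acetamido is accommodated at this position without a shift beyond the scatter. For the compounds shown here, the earlier step concerned a different ring, which makes this the first reading on the sulfonyl phenyl. No supporting data bear on this result.

On these data alone, whether an amine, a carboxylic acid or a longer chain at this position would move the number beyond the scatter remains open. Also open, as far as these compounds go, is whether acetamido gives the same reading with fluoro in place of trifluoromethyl on the other ring.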